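Sulfur for Oxygen on a Fused Diamine Core

The compounds below may be only part of what the source reports. "The series", "measured", "known", "first", "only" and "open" are said of these compounds alone.

Compound 1 `Nc1cc(N)c2nc(-c3ccccc3)c(NCc3ccc(F)cc3)nc2c1` in a functional assay on HCT-15 cells (Homo sapiens) for inhibition, read by sulforhodamine B assay, with a stated time of 48 h (on this read-out lower numbers stand for stronger inhibition of growth and higher numbers for weaker inhibition of growth), gives 19100 nM. Compound 2 `Nc1cc(N)c2nc(-c3ccccc3)c(Oc3ccc(F)cc3)nc2c1` returns only a limit in this assay, < 100000 nM. The step that the limit leaves unreadable from compound 1 to compound 2 cannot therefore be read, owing to the limit of < 100000 nM in this assay, at which 1 of the 2 values shown sits. Compound 3 `Nc1cc(N)c2nc(-c3ccccc3)c(Sc3ccc(F)cc3)nc2c1` differs from compound 2 by (4-fluorophenyl)sulfanyl in place of 4-fluorophenoxy on an aromatic carbon. Within the data shown here, no measured step bears readably on this change, so no shift beyond the scatter is expected for compound 3 in this assay. The step that this estimate implies, a step that the limit leaves unreadable from compound 2 to compound 3, is given with wide bounds. Compound 3 is expected to give 30000 nM, within a range from 8000 nM to 100000 nM.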

Compound 3, concentration for total growth inhibition: 27500 nM
Estimate against measurement, compound 3: 1.1-fold (0.04 log units) above, and the stated range covers the measured number.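

In this assay, (4-fluorophenyl)sulfanyl in place of (4-fluorobenzyl)amino on this aromatic carbon next to the ring nitrogen gives a 1.4-fold higher number from compound 1 to compound 3 (0.16 log units; within the scatter). The position therefore carries either of these two groups with no difference that can be read between them. The steps that involve compound 2 cannot be read, and its value is only a limit: the limit of < 100000 nM in this assay, at which 1 of the 3 values shown sits.

As far as these compounds go, it remains open whether the oxygen and sulfur links differ at all. From the compounds shown here alone, it is also open how a primary amine or a longer alkyl chain would behave on this carbon.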